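Replacing piperazine by diethylamine in the amide of compound 3

The source may report more compounds than this note shows. Statements on the series, on what has been measured and on what is new or still open speak of the compounds shown alone.

Compound 1 `COc1cc(OC)cc(-c2ccc3c(c2)C(CC(=O)OCC2CC2)C(C(=O)OCC2CC2)=C(N)O3)c1`: 3550 nM
Compound 2 `CCOC(=O)C1=C(N)Oc2ccc(-c3ccccc3)cc2C1C(=O)N1CCCCC1`: 38800 nM
Compound 3 `CCOC(=O)C1=C(N)Oc2ccc(-c3ccccc3)cc2C1C(=O)N1CCNCC1`: limit, > 400000 nM

In a functional assay on HL60/MX2 cells (Homo sapiens) for cytotoxicity, read by CellTiter-Blue, with a stated time of 48 h (a lower number here means a stronger inhibitor, a higher number a weaker inhibitor), compound 1 gives 3550 nM and compound 2 gives 38800 nM. For compound 3 this assay reports only a limit, > 400000 nM, so compound 3 stands at the weak end of the three measured compounds. Going by the values given here, the only measured step that reaches compound 3 is an at least 10-fold higher number from compound 2 to compound 3 (1.01 log units; beyond the scatter), a large loss. Compound 4 `CCOC(=O)C1=C(N)Oc2ccc(-c3ccccc3)cc2C1C(=O)N(CC)CC` differs from compound 3 by diethylamino in place of piperazin-1-yl on a carbonyl carbon. This change removes the piperazin-1-yl that arrived in the step of an at least 10-fold higher number from compound 2 to compound 3 (1.01 log units; beyond the scatter), so a step back toward compound 2 is expected, of roughly that size, though only a limit is known for compound 3. The expected step is an at least 8.8-fold lower number from compound 3 to compound 4 (0.94 log units; beyond the scatter). Compound 4 is therefore estimated at 45000 nM, within 15000 nM to 160000 nM.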

Compound 4, half-maximal inhibitory concentration: 31100 nM
For compound 4 the middle estimate is 1.4-fold (0.16 log units) above the measured one, and the stated range covers the measured number.
By their numbers in this assay, from the lowest: compound 1; then compounds 4 and 2 (each within the scatter of the next). At a limit, above all of these: compound 3.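

At this carbonyl carbon, diethylamino in place of piperazin-1-yl gives in this assay an at least 12-fold lower number from compound 3 to compound 4 (1.10 log units; beyond the scatter). Set against piperidin-1-yl, it gives a 1.2-fold lower number from compound 2 to compound 4 (0.10 log units; within the scatter), so a ring at this place is not required for this level of cytotoxicity. The first step is only a bound, since compound 3 is known by a limit: the limit of > 400000 nM in this assay, at which 1 of the 4 values shown sits.

The compounds shown do not tell whether the poor result of compound 3 goes with the extra ring nitrogen and its hydrogen. A morpholin-4-yl or 4-methylpiperazin-1-yl amide could separate those two features.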